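Solubility notes: cyclopropyl to cyclopentylmethyl on the carbonyl

This account rests on a few compounds, and the source may have more. Where it says the series, first, only, none or still open, it means among the compounds named here.

Measured in a physicochemical assay for solubility, read by HPLC, in phosphate buffer, measured as kinetic solubility, at pH 7.4; a higher number here means a more soluble compound, a lower number a less soluble compound
- compound 1 `CC(C)(C)C(=O)c1cc(-c2ccc(S(N)(=O)=O)cc2)n(-c2ccc(Cl)cc2)n1` gives 6600 nM
- compound 2 `NS(=O)(=O)c1ccc(-c2cc(C(=O)C3CC3)nn2-c2ccc(Cl)cc2)cc1` gives 25600 nM

Compound 2 holds the higher of the two numbers, and its gap to compound 1 lies beyond the scatter. Next comes compound 3 `NS(=O)(=O)c1ccc(-c2cc(C(=O)CC3CCCC3)nn2-c2ccc(Cl)cc2)cc1`, not yet measured, which carries cyclopentylmethyl in place of cyclopropyl on a carbonyl carbon.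

Going by the values given here, only one measured step bears on this change, and it sits at the same place: a 3.9-fold higher number from compound 1 to compound 2 (0.59 log units; beyond the scatter) with cyclopropyl in place of tert-butyl. That step is modest but beyond the scatter. Among the compounds with values here, it is a single pair, and no measured compound carries cyclopentylmethyl, so the basis for any forecast is thin. Cyclopropyl gave the higher number in that pair, so leaving it is expected to lower the number in this assay by a similar or somewhat larger amount. The expected change is estimated as follows (a 5.7-fold lower number from compound 2 to compound 3 (0.76 log units; beyond the scatter)). For compound 3 the estimated value is 4500 nM (expected range 1200 nM to 15000 nM).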

Compound 3, solubility: 2600 nM
For compound 3 the middle estimate is 1.7-fold (0.24 log units) above the measured one, and the stated range covers the measured number.
By their numbers in this assay, from the lowest: compound 3; then compound 1; then compound 2.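

Working notes on the carbonyl substituent: in this assay, the change to cyclopentylmethyl gives a 9.8-fold lower number from compound 2 to compound 3 (0.99 log units; beyond the scatter), so this position tolerates a wider spread of numbers than the first pair alone could show. The new compound also ranks under the tert-butyl compound, with a 2.5-fold lower number from compound 1 to compound 3 (0.40 log units; beyond the scatter), and both steps lie beyond the scatter; leaving cyclopropyl therefore does not lead to one shared level, and the three carbon-only groups give three separate numbers, with cyclopropyl highest and cyclopentylmethyl lowest. No measurement on these compounds accounts for this order.

The three compounds cannot separate the effect of the ring from that of the added methylene link, and a directly attached cyclopentyl or a cyclobutyl would be needed to divide the change from cyclopropyl to cyclopentylmethyl into its parts. It also remains open how this assay would read for a group on the same carbonyl carbon that carries an amine or a carboxylic acid, since every substituent shown consists of carbon alone.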